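The source may report more compounds than this note shows. Statements on the series, on what has been measured and on what is new or still open speak of the compounds shown alone.

Among the measured compounds shown here, in a functional assay on HeLa cells (Homo sapiens) for antiproliferative activity, read by XTT assay, with a stated time of 72 h (a higher number here means a weaker inhibitor, a lower number a stronger inhibitor), compound 1 (`C=C(C)CCC[C@]1(C)C2=CCC[C@](C)(C[C@H](OC(C)=O)C3=CC(=O)OC3O)[C@H]2CC[C@H]1C`) gives 2600 nM and compound 2 (`C=C(C)CCC[C@]1(C)C2=CCC[C@](C)(C[C@@H](OC(C)=O)C3=CC(=O)OC3O)[C@H]2CC[C@H]1C`) gives 3500 nM as its only measured neighbour. Between them lies a 1.3-fold higher number from compound 1 to compound 2 (0.13 log units; within the scatter) and nothing more: the atoms and bonds are the same, and only a stereocentre at a saturated chain carbon differs. Compound 1 therefore holds no separate place on these numbers.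

Compound 3 (`C=C(C)CCC[C@]1(C)C2=CCC[C@](C)(C[C@H](O)C3=CC(=O)OC3O)[C@H]2CC[C@H]1C`) has not yet been measured. It departs from compound 1 by acetoxy to hydroxy (hydrogen in place of acetyl on an oxygen on a saturated carbon), which puts hydrogen in place of acetyl on an oxygen on a saturated carbon.

For the measured compounds named here, no measured step removes an acetyl group. Going by the values given here, the one step available, a 1.3-fold higher number from compound 1 to compound 2 (0.13 log units; within the scatter) as it stands, concerns configuration only and so bears on this change only indirectly. Starting from compound 1 at 2600 nM as the anchor, no step beyond the scatter is expected in this assay and there is only a slight lean towards a higher number. The estimated move is a 1.5-fold higher number from compound 1 to compound 3 (0.19 log units; within the scatter) on this expectation. For compound 3 the estimated value is 4000 nM with 1300 nM to 12000 nM as the expected range, kept wide for want of a direct precedent.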

Compound 3, half-maximal inhibitory concentration: 3800 nM
Compound 3: the middle estimate sits 1.1-fold (0.02 log units) above what was measured, and the stated range covers the measured number.
By their numbers in this assay, from the lowest: compounds 1, 2 and 3 (each within the scatter of the next).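

Up to this point the series offered only a change of configuration; compound 3 adds the first change in atoms and bonds, with hydrogen in place of acetyl on an oxygen on a saturated carbon. In this assay the exchange of acetoxy to hydroxy gives a 1.5-fold higher number from compound 1 to compound 3 (0.16 log units; within the scatter) and so does not move the number beyond the scatter. With the configuration of compound 1 kept, the acetyl group is therefore not needed for the antiproliferative activity to stay at the level of compound 1, and the free hydroxy serves equally well on these numbers.

The compounds shown leave open whether this holds for the hydroxy partner of compound 2, and whether a longer acyl chain, a methyl ether or an amine in place of the hydroxy would also leave the number within the scatter. Nothing measured here bears on why the exchange of acetoxy to hydroxy gives so small a step.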